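A few compounds are considered here, and "the series" means these few. Any claim that something is new, unique, unknown or untested is made for them only; others in the source may bear on it.

Measured so far:
compound 1 `Cc1ccc(OCC(=O)N(Cc2cccs2)c2ncco2)cc1` — 0.3 nM
compound 2 `Cc1ccc(OCC(=O)N(Cc2cccs2)c2c(C)n[nH]c2C)cc1` — 0.3 nM

In an assay on HEK293 cells for agonist activity at transient receptor potential cation channel subfamily M member 8 (Homo sapiens), read by fluorescence and calcium flux, with a stated time of 15 min (on this read-out lower numbers stand for an effect already at smaller amounts and higher numbers for an effect only at larger amounts of compound), compound 2 gives 0.3 nM, level with compound 1 at the digits printed, and the step of no change at the digits printed from compound 1 to compound 2 (within the scatter) lay within the scatter. Compound 3 `Cc1ccc(OCC(=O)N(Cc2cccs2)c2cn[nH]c2)cc1` carries a smaller change: 1H-pyrazol-4-yl in place of 3,5-dimethyl-1H-pyrazol-4-yl on an amide-type nitrogen. Among the measured compounds shown here, only that one measured step exists, and it exchanged a whole ring without moving the read-out, so it bears on this change only loosely. With no closer guide, the step of a 2.7-fold higher number from compound 2 to compound 3 (0.43 log units; beyond the scatter) is expected to stay small. Compound 3 is therefore estimated at 0.8 nM, with a range from 0.2 nM to 4 nM.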

Compound 3, half-maximal effective concentration: 1.4 nM
Compound 3: middle estimate off by 1.8-fold (0.24 log units), on the low side, within the range that was stated.
By their numbers in this assay, from the lowest: compounds 1 and 2 (each within the scatter of the next); then compound 3.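

Taking the methyl groups off the 3,5-dimethyl-1H-pyrazol-4-yl on the amide-type nitrogen does register in this assay, with a 4.7-fold higher number from compound 2 to compound 3 (0.67 log units; beyond the scatter). Replacing 1,3-oxazol-2-yl with 1H-pyrazol-4-yl at the same place gives a 4.7-fold higher number from compound 1 to compound 3 (0.67 log units; beyond the scatter), so this position does not treat every five-membered aromatic ring alike, as the first ring exchange alone might have suggested. No measurement shown explains this rise. Still open, going by these compounds, is whether a single methyl on the 1H-pyrazol-4-yl would restore the lower number, and how an ethyl group or an amine on that ring would read.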